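The compounds below may be only part of what the source reports. "The series", "measured", "known", "first", "only" and "open" are said of these compounds alone.

Measured compounds:
- compound 1, `COc1ccc(N2CCN(Cc3csc(N)c3C(=O)c3ccc(Cl)cc3)CC2)cc1`, giving -52%
- compound 2, `Nc1scc(CN2CCN(c3ccccc3C(F)(F)F)CC2)c1C(=O)c1ccc(Cl)cc1`, giving -60%
- compound 3, `Nc1scc(CN2CCN(c3ccncc3)CC2)c1C(=O)c1ccc(Cl)cc1`, giving -15%

These three values come from a functional assay on CHO cells with adenosine receptor A1 (Homo sapiens) as the target, read by cAMP accumulation and immunoassay, with a stated time of 6 min, tested at 10 uM; a higher number here means a weaker effect of the compound at the concentration tested, a lower number a stronger effect. Compound 1 stands second highest of the three: its nearest neighbour is compound 2, with a number 8 percentage points lower from compound 1 to compound 2 (within the scatter), and the furthest is compound 3, with a number 37 percentage points higher from compound 1 to compound 3 (beyond the scatter). The same picture appears in a number 45 percentage points higher from compound 2 to compound 3 (beyond the scatter). In both large steps the group that enters is pyridin-4-yl; in the small step one six-membered aromatic ring of carbon only is exchanged for another.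

Compound 4, `Nc1scc(CN2CCN(c3ccc(F)c(F)c3)CC2)c1C(=O)c1ccc(Cl)cc1`, has not yet been measured in this assay. Its change from compound 1 is 3,4-difluorophenyl in place of 4-methoxyphenyl on an amine nitrogen in a ring. As in the step from compound 1 to compound 2, a six-membered aromatic ring of carbon only stays in place, so the step that bears on it is the small one, and no step beyond the scatter is expected; the large steps to compound 3 concern a different kind of ring and are not taken as a guide. Compound 4 is therefore expected to sit near compound 1 and compound 2, with a number 3 percentage points lower from compound 1 to compound 4 (within the scatter), that is an estimated -55%, between -78% and -30%.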

Compound 4, a percentage reported as activity, at one concentration (the size of the read-out at that concentration, not a potency): -87%
For compound 4 the middle estimate is 32 percentage points above the measured one; the measured number lies below the stated range.
By their numbers in this assay, from the lowest: compound 4; then compounds 2 and 1 (each within the scatter of the next); then compound 3.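

In this assay, keeping a six-membered aromatic ring of carbon only on the amine nitrogen does not fix the read-out: exchanging 4-methoxyphenyl for 3,4-difluorophenyl gives a number 35 percentage points lower from compound 1 to compound 4 (beyond the scatter), so what that ring carries matters here as well as the kind of ring. The earlier exchange between two such rings stayed within the scatter, but this one does not, with a number 27 percentage points lower from compound 2 to compound 4 (beyond the scatter), and the span at this position also grows to a number 72 percentage points lower from compound 3 to compound 4 (beyond the scatter), which leaves compound 4 with the strongest effect of the four and compound 3 with the weakest. No measurement of any property of these groups accompanies the result, and the data offer no explanation for this shift.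

The compounds shown leave open whether a phenyl ring with a single fluorine, or an unsubstituted phenyl ring, would behave like 3,4-difluorophenyl, and whether a ring carrying chlorine or a nitrile would do the same. From the compounds shown here alone, each read-out also comes from one concentration, so how the compounds rank in potency remains open.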